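This account rests on a few compounds, and the source may have more. Where it says the series, first, only, none or still open, it means among the compounds named here.

In an assay on CHO cells for positive allosteric modulation of adenosine receptor A1 (Homo sapiens), read by ERK phosphorylation, tested at 3 uM (a lower number here means a stronger effect, a higher number a weaker effect of the compound at the concentration tested), compound 1 `Nc1sc(-c2ccccc2)cc1C(=O)c1ccccc1` gives 12%. For the measured compounds named here, compound 2 `Nc1sc(-c2cncnc2)cc1C(=O)c1ccccc1` gives 18% in the same assay; among the two numbers measured so far it stands highest, its nearest neighbour being compound 1, and the step of a number 6 percentage points higher from compound 1 to compound 2 (within the scatter) lies within the scatter, so the two compounds are not told apart by this read-out.

Compound 3 `Nc1sc(-c2ccncc2)cc1C(=O)c1ccccc1` is the next compound, and it differs from compound 2 by pyridin-4-yl in place of pyrimidin-5-yl on an aromatic carbon. Going by the values given here, only one measured step bears on this change: the exchange of phenyl for pyrimidin-5-yl at the same place, a number 6 percentage points higher from compound 1 to compound 2 (within the scatter), which stayed within the scatter. With two aromatic six-membered rings at this position giving numbers so close together, a third such ring is expected to give a step of a number 3 percentage points lower from compound 2 to compound 3 (within the scatter) that does not rise beyond the scatter. For compound 3 a value of 15% is therefore estimated, expected to fall between 4% and 27%.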

Compound 3, a percentage reported as activity, at one concentration (the size of the read-out at that concentration, not a potency): 23%
Estimate against measurement, compound 3: 8 percentage points below; the range from low to high includes it.
By their numbers in this assay, from the lowest: compounds 1, 2 and 3 (each within the scatter of the next, the first and the last beyond it).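

Pyridin-4-yl in place of pyrimidin-5-yl on this aromatic carbon, next to the ring sulfur, gives a number 5 percentage points higher from compound 2 to compound 3 (within the scatter) in this assay, so these two rings are not told apart by this read-out. Pyridin-4-yl in place of phenyl at the same place gives a number 11 percentage points higher from compound 1 to compound 3 (beyond the scatter) in this assay, the only step among the three compounds that passes the scatter, and only modestly, so this position is not wholly indifferent to which six-membered aromatic ring it carries. Nothing available explains why this one step passes the scatter while the other two do not.

All the groups shown at this place are six-membered aromatic rings, so it stays open whether pyridin-3-yl, a morpholine, a carboxylic acid or a short alkyl chain would give a number in the same range. As far as these compounds go, it also stays open whether the modest step seen with pyridin-4-yl would hold with another group on the ring atom that bears the amino group.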